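The compounds below may be only part of what the source reports. "The series", "measured", "known", "first", "only" and "open" are said of these compounds alone.

Working notes on the series. In a functional assay on HT-29 cells (Homo sapiens) for cytotoxicity, read by sulforhodamine B assay, with a stated time of 2 days, tested at 100 uM (a higher number here means more inhibition at the concentration tested (going by the name of the read-out), a lower number less inhibition), compound 1 `CCCc1n[nH]c2c(=O)n(NC(=O)c3ccncc3)c(-c3cccc(OC)c3)nc12` gives 0.07%, the lowest of the three numbers shown. Compound 2 `COc1cccc(-c2nc3c(-c4ccc(Cl)cc4)n[nH]c3c(=O)n2NC(=O)c2ccncc2)c1` gives 46% and compound 3 `COc1cccc(-c2nc3c(-c4ccc(C5CCNCC5)cc4)n[nH]c3c(=O)n2NC(=O)c2ccncc2)c1` gives 28.1%; the steps of a number 45.9 percentage points higher from compound 1 to compound 2 (beyond the scatter), a number 28 percentage points higher from compound 1 to compound 3 (beyond the scatter) and a number 17.9 percentage points lower from compound 2 to compound 3 (beyond the scatter) all concern the aromatic carbon that carries propyl in compound 1, and all lie beyond the scatter.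

Compound 4 `CCCc1n[nH]c2c(=O)n(NC(=O)c3ccccc3)c(-c3cccc(OC)c3)nc12` differs from compound 1 in a different part of the molecule: phenyl in place of pyridin-4-yl on a carbonyl carbon. Among the compounds with values here, the carbonyl carbon bearing this group sits on the amide-type nitrogen, and none of the measured steps changes anything there. Within the data shown here, the three measured steps therefore do not bear on this change, and the data give no step of comparable kind on which to build. With the remainder of compound 1 kept intact, and compound 1 itself giving 0.07%, the expectation is for a step of a number 4.9 percentage points higher from compound 1 to compound 4 (within the scatter), that is no change beyond the scatter. Compound 4 is estimated at 5% in this assay, within a range from 0% to 25%.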

Compound 4, a percentage reported as inhibition, at one concentration (the size of the read-out at that concentration, not a potency): 6.27%
Beside the measured number, compound 4's estimate is 1.3 percentage points below it, and the stated range covers the measured number.
By their numbers in this assay, from the lowest: compounds 1 and 4 (each within the scatter of the next); then compound 3; then compound 2.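

Within the data shown here, this is the first reading at the carbonyl carbon on the amide-type nitrogen, a place none of the earlier steps touched. In this assay, the change from pyridin-4-yl to phenyl removes the ring nitrogen and its hydrogen-bond acceptor, yet gives a number 6.2 percentage points higher from compound 1 to compound 4 (within the scatter), so with propyl on the aromatic carbon this change does not separate the two compounds. No measurement here offers an explanation for this result.

Going by these compounds, it remains open whether the same change would also stay within the scatter with the 4-chlorophenyl of compound 2 or the 4-(piperidin-4-yl)phenyl of compound 3 in place of propyl. Also open, on these data alone, is how a group of another kind on the carbonyl carbon, such as cyclohexyl or a longer chain ending in an amine, would read.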